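Swapping a ring substituent: from compound 2 to compound 4

This account rests on a few compounds, and the source may have more. Where it says the series, first, only, none or still open, it means among the compounds named here.

Measured compounds:
compound 1, `N/C(=N\NC(=S)N1CCOCC1)c1ccccn1`, 82.8%
compound 2, `N/C(=N\NC(=S)N1CCN(c2ccccn2)CC1)c1ccc(F)cn1`, 87%
compound 3, `Cc1ccnc(/C(N)=N/NC(=S)N2CCCCC2)c1`, 69.1%

All three were tested in a functional assay on HeLa cells (Homo sapiens) for cytotoxicity, read by MTT assay, with a stated time of 72 h, tested at 30 uM; on this read-out lower numbers stand for less inhibition of growth and higher numbers for more inhibition of growth at the one concentration tested. Compound 2 gives the highest of the three numbers, yet its nearest neighbour, compound 1, stands within the usual scatter of it, so no order between these two can be claimed. Compound 3 lies clearly lower than compound 2, beyond the scatter; the two differ in more than one place, so only the two values themselves can be compared.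

The unmeasured compound 4, `Cc1ccnc(/C(N)=N/NC(=S)N2CCN(c3ccccn3)CC2)c1`, differs from compound 2 in a single place: 4-methylpyridin-2-yl in place of 5-fluoropyridin-2-yl on a carbon with a double bond to nitrogen. The ring that enters is the same one carried by compound 3, whose value in this assay is the lowest of the three, while the rest of compound 4 matches compound 2. Going by the values given here, no measured pair that differs only in this way is available, so the size of the step is uncertain. A modest drop in this assay is expected for compound 4, estimated as a number 9 percentage points lower from compound 2 to compound 4 (within the scatter), possibly still inside the scatter. The expected value for compound 4 in this assay is 78%, within a range from 60% to 92%.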

Compound 4, percent growth inhibition at one concentration: 77%
Estimate against measurement, compound 4: 1 percentage points above; measured number inside the range.
By their numbers in this assay, from the lowest: compounds 3, 4, 1 and 2 (each within the scatter of the next, the first and the last beyond it).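

In this assay, going by these compounds alone, the exchange of 5-fluoropyridin-2-yl for 4-methylpyridin-2-yl on a carbon with a double bond to nitrogen gives a number 10 percentage points lower from compound 2 to compound 4 (within the scatter), and this is the first comparison in which only this group differs. At this position, then, the two rings cannot be told apart in this assay, so a fluorine on the ring can be exchanged for a methyl group, at a different place on the ring, without a change that exceeds the usual scatter, at least with the rest of compound 2 held constant. Nothing available here explains the size of this step or shows what either ring contributes to growth inhibition.

The compounds shown leave open whether a more different group on this carbon, such as a phenyl ring without a ring nitrogen or a pyridine ring bearing a carboxylic acid or an amine, would give a step beyond the scatter. Within the data shown here, they also leave open whether the same exchange would give a similar step in compounds with a different group on the thiocarbonyl carbon, such as the one in compound 1.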